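Working notes: replacing the 4-nitrophenyl of compound 2

The compounds below may be only part of what the source reports. "The series", "measured", "known", "first", "only" and "open" are said of these compounds alone.

Values so far in a physicochemical assay for lipophilicity, measured as octanol-water partition (on this read-out lower numbers stand for lower lipophilicity and higher numbers for higher lipophilicity), are these
- compound 1 `COc1cc(/C=N/c2ccccc2C(=O)NNc2ccnc3cc(Cl)ccc23)cc(OC)c1OC` gives 4.94
- compound 2 `O=C(NNc1ccnc2cc(Cl)ccc12)c1ccccc1/N=C/c1ccc([N+](=O)[O-])cc1` gives 4.58
- compound 3 `CN(C)c1ccc(/C=N/c2ccccc2C(=O)NNc2ccnc3cc(Cl)ccc23)cc1` gives 5.03

Compound 2 stands lowest of the three at 4.58 on this scale, and the other two compounds both lie higher, beyond the scatter. Compound 4 `O=C(NNc1ccnc2cc(Cl)ccc12)c1ccccc1/N=C/c1cc2ccccc2[nH]c1=O` is not yet measured. Its structural change is a group of 11 heavy atoms (9 carbon, 1 nitrogen, 1 oxygen; one six-membered aromatic ring of carbon only, one six-membered aromatic ring with 1 hetero atom) in place of a group of 9 heavy atoms (6 carbon, 1 nitrogen, 2 oxygen; one six-membered aromatic ring of carbon only), on a carbon with a double bond to nitrogen so the 4-nitrophenyl leaves as a whole. Among the compounds with values here, the only measured step bearing on this is a number 0.45 log units higher from compound 2 to compound 3 (beyond the scatter) for dimethylamino in place of nitro on an aromatic carbon. That step swaps a substituent rather than the whole group, so it guides only loosely. A modest rise is expected in this assay and no change beyond the scatter remains possible. The estimated step is a number 0.22 log units higher from compound 2 to compound 4 (within the scatter) on this reading. For compound 4 the estimate is 4.8 with an expected range from 4.35 to 5.25 on the same scale.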

Compound 4, partition coefficient: 4.65
For compound 4 the middle estimate is 0.15 log units above the measured one, within the range that was stated.
By their numbers in this assay, from the lowest: compounds 2, 4, 1 and 3 (each within the scatter of the next, the first and the last beyond it).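

Replacing the 4-nitrophenyl whole with the group of 11 heavy atoms, on a carbon with a double bond to nitrogen, gives a number 0.07 log units higher from compound 2 to compound 4 (within the scatter) in this assay, so this position accepts a second aromatic ring with no change beyond the scatter. The same group gives a number 0.38 log units lower from compound 3 to compound 4 (beyond the scatter) when it replaces the dimethylamino-bearing group, so the read-out at this position differs with the group that leaves. No measurement at hand accounts for either step.

Going by these compounds, whether a pyridine ring or a phenyl bearing a carboxylic acid at this carbon would stay within the same span remains open.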